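Solubility of a cyanophenyl sulfonamide estimated from a chlorophenyl analogue

The source may hold more compounds than are shown below. What is called first, only, known or untested is meant among the compounds shown, and "the series" means these compounds.

Among the compounds with values here, compound 1, `N#Cc1ccc(O[C@H]2CN(S(=O)(=O)c3ccc(Cl)cc3)C[C@@]2(O)CO)cc1F`, is the only compound of this set with a plain number in a physicochemical assay for solubility, in simulated intestinal fluid, with a stated time of 4 h; a lower number here means a less soluble compound, a higher number a more soluble compound: there compound 1 gives 44 ug/mL. Compound 2, `N#Cc1ccc(S(=O)(=O)[C@H]2CN(S(=O)(=O)c3ccc(Cl)cn3)C[C@@]2(O)CO)cc1`, does not give a number in this assay, only a limit: compound 2 reports > 1000 ug/mL. Compound 3, `N#Cc1ccc(O[C@H]2CN(S(=O)(=O)c3ccc(Cl)cn3)C[C@@]2(O)CN)cc1F`, likewise reaches a limit in this assay, where compound 3 reports > 1000 ug/mL. Thus compound 1 stands alone below (the limit of > 1000 ug/mL in this assay, at which 2 of the 3 values shown sit), and no step between two measured compounds is available. Compound 4, `N#Cc1ccc(O[C@H]2CN(S(=O)(=O)c3ccccc3C#N)C[C@@]2(O)CO)cc1F`, is not yet measured. It differs from compound 1 in one place: 2-cyanophenyl in place of 4-chlorophenyl on a sulfonyl sulfur. Within the data shown here, with no measured step to lean on, the change is expected to move this assay upward by a modest amount, beyond the scatter but short of the limit, so that compound 4 is estimated at 150 ug/mL, between 40 ug/mL and 600 ug/mL, a step of a 3.4-fold higher number from compound 1 to compound 4 (0.53 log units; beyond the scatter) relative to compound 1.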

Compound 4, solubility: 20 ug/mL
Compound 4: the middle estimate sits 7.5-fold (0.88 log units) above what was measured; measured number below the stated range.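

Within the data shown here, on the sulfonyl sulfur, 2-cyanophenyl in place of 4-chlorophenyl gives the first measured step at this position in this assay, and it is a 2.2-fold lower number from compound 1 to compound 4 (0.34 log units; beyond the scatter). The change brings in a nitrile and one hydrogen-bond acceptor, yet the number goes down rather than up, so at this place that swap does not lift the read-out. Compound 4 gives a plain number, as compound 1 does, and stays short of the limit of the assay: the limit of > 1000 ug/mL in this assay, at which 2 of the 4 values shown sit.

The compounds shown offer no second pair with this change, and they give no measured reason for the step. On these data alone, whether an amine or a carboxylic acid on this phenyl ring would move the number towards the limit remains open.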